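The source may hold more compounds than are shown below. What is called first, only, known or untested is meant among the compounds shown, and "the series" means these compounds.

Of the compounds shown here, three built on one shared core have been tested in an assay on HEK293 cells for displacement of a labelled ligand from adenosine receptor A2b (Homo sapiens), read by scintillation counting, with a stated time of 30 min, tested at 10 uM; on this read-out higher numbers stand for more inhibition at the one concentration tested (going by the name of the read-out) and lower numbers for less inhibition. Compound 1 `COCCNC(=O)c1cc2cccc(OC)c2oc1=N` gives 43%. Compound 3 `COCCNC(=O)c1cc2cccc(OC)c2oc1=O` gives 18%, and compound 2 `O=C(NC1CCCC1)c1cc2ccccc2oc1=O` gives 18%. Compound 2 therefore stands level with compound 3 at the digits shown, the two of them together the lowest of the three numbers, while compound 1 lies a good way higher, a gap that goes beyond the usual scatter of such measurements.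

Compound 4 `O=C(O)CNC(=O)c1cc2ccccc2oc1=O` has not yet been measured in this assay. It differs from compound 2 in one place: carboxymethyl in place of cyclopentyl on an amide-type nitrogen. Within the data shown here, no pair of measured compounds differs by this kind of change, so there is no measured step to lean on, and the expectation rests on the number for compound 2 alone. Because compound 2 gives only 18%, the expected step is a number 4 percentage points lower from compound 2 to compound 4 (within the scatter), nothing beyond the scatter in either direction. Compound 4 is accordingly expected to give 14%, with a range from 0% to 32%. What the assay actually reports for compound 4 is the next thing to see.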

Compound 4, a percentage reported as inhibition, at one concentration (the size of the read-out at that concentration, not a potency): 9%
The estimate for compound 4 lay 5 percentage points above the measured number, and the stated range covers the measured number.
By their numbers in this assay, from the lowest: compounds 4, 2 and 3 (each within the scatter of the next); then compound 1.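

In this assay, carboxymethyl in place of cyclopentyl on an amide-type nitrogen gives a number 9 percentage points lower from compound 2 to compound 4 (within the scatter), the first step measured at this position. The two compounds cannot be told apart on this measurement, even though the group that enters has no ring and carries a hydrogen-bond donor and a hydrogen-bond acceptor, while the group that leaves is a five-membered ring of carbon only with neither. So this exchange, large as it looks on paper, moves the number by no more than repeated measurements might, and nothing measured on these compounds speaks to why the two numbers stay so close.

Still open, on these data alone, is whether any other group on this nitrogen would shift the number beyond the scatter, for example an aminoethyl group, the methyl ester of the carboxylic acid, or a longer chain such as carboxypropyl. Also open, as far as these compounds go, is whether the same exchange would read the same way on the core of compound 1, which gives 43% with its own side chain.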